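The source may report more compounds than this note shows. Statements on the series, on what has been measured and on what is new or still open speak of the compounds shown alone.

Working notes on the series. All four compounds share the same core, and they differ in the chain that joins it to the phenyl ring bearing the oxyacetic acid or its ester. Compound 1 `O=C(O)COc1cccc(/C=C\c2nc(-c3ccccc3)c(-c3ccccc3)o2)c1` has an olefin link and the free acid. Compound 2 `CCOC(=O)/C(=C\c1cccc(OCC(=O)OC(C)(C)C)c1)c1nc(-c2ccccc2)c(-c2ccccc2)o1` carries an ethyl ester on the olefin and a tert-butyl ester in place of the free acid. Compound 3 `COC(=O)C(Cc1cccc(OCC(=O)O)c1)c1nc(-c2ccccc2)c(-c2ccccc2)o1` has a saturated link, a methoxycarbonyl on it and the free acid.

In a functional assay for inhibition, with Homo sapiens as the target (a lower number here means a stronger inhibitor, a higher number a weaker inhibitor), compound 1 gives 180 nM. For compound 2 the assay reports only a limit, > 60000 nM, which is the limit of > 60000 nM in this assay, at which 1 of the 3 values shown sits. Compound 3 gives 80 nM, the lowest of the two numbers available; the nearest is compound 1, whose number is higher by a margin beyond the usual scatter.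

Compound 4 `O=C(O)COc1cccc(CC(c2ccsc2)c2nc(-c3ccccc3)c(-c3ccccc3)o2)c1` is not yet measured. It differs from compound 3 by thiophen-3-yl in place of methoxycarbonyl on a saturated chain carbon bound to an aromatic carbon and a saturated chain carbon. Among the compounds with values here, no measured pair shows this exchange, so the step is open. The free acid and the saturated link of compound 3 are retained, and the change is confined to the substituent on that chain carbon; a step from compound 3 to compound 4 of about a 1.4-fold higher number from compound 3 to compound 4 (0.14 log units; within the scatter) in this assay is expected, within or close to the scatter. For compound 4 the estimate in this assay is 110 nM, with a range from 30 nM to 450 nM.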

Compound 4, half-maximal inhibitory concentration: 20700 nM
Compound 4: the middle estimate sits 190-fold (2.27 log units) below what was measured, and the stated range ends below it.
By their numbers in this assay, from the lowest: compound 3; then compound 1; then compound 4. At a limit, above all of these: compound 2.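

At the saturated chain carbon bound to an aromatic carbon and a saturated chain carbon, the substituent strongly affects the result: in this assay, thiophen-3-yl in place of methoxycarbonyl brings a 260-fold higher number from compound 3 to compound 4 (2.41 log units; beyond the scatter) with the free acid and the saturated link unchanged. The earlier compounds shown here offered no pair differing in one place, so they gave no separate reading of this position, and compound 1 and compound 3 alone could not show that the free acid on a saturated or olefin link does not by itself secure a low number. The single limit in the series concerns another compound and gives no reason for this step.

Still open, from the compounds shown here alone, is whether the step reflects the loss of methoxycarbonyl or the arrival of thiophen-3-yl, a question that a primary amide or a methyl group on the same carbon could help to separate. Within the data shown here, also open is whether the same exchange would carry a similar penalty on the olefin link, where the series offers no matched pair.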